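The compounds below may be only part of what the source reports. "The series", "measured", "known", "first", "only" and "open" are said of these compounds alone.

Of the compounds shown here, three built on one shared core have been tested in an assay on isolated protein for inhibition of Amine oxidase [flavin-containing] B (Bos taurus); a higher number here means a weaker inhibitor, a lower number a stronger inhibitor. Compound 1 `CCC(=O)N1N=C(c2ccccc2)CC1c1ccc(C)cc1` gives 100000 nM. Compound 2 `CCC(=O)N1N=C(c2ccc(C)cc2)CC1c1ccc(C)cc1` carries a methyl in place of a hydrogen on an aromatic carbon and gives 100000 nM; the step of no change at the digits printed from compound 1 to compound 2 (within the scatter). Compound 3 `CCC(=O)N1N=C(c2ccc(OC)cc2)CC1c1ccc(F)cc1` gives 100000 nM, which leaves it level with compounds 1 and 2 at the digits shown, compound 1 being the nearest and compound 2 the furthest, both within the scatter.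

Compound 4 `CCC(=O)N1N=C(c2ccc(OC)cc2)CC1c1ccc(C)cc1` has not yet been measured. It differs from compound 3 by methyl in place of fluoro on an aromatic carbon. For the measured compounds named here, the only measured step that speaks to such a swap on an aromatic carbon is no change at the digits printed from compound 1 to compound 2 (within the scatter), which moved nothing beyond the scatter. Every substituent change seen so far has left this assay unmoved, and no movement beyond the scatter is expected here either. Compound 4 is therefore estimated at 100000 nM, with a range from 50000 nM to 200000 nM, an expected step of no change at the digits printed from compound 3 to compound 4 (within the scatter).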

Compound 4, half-maximal inhibitory concentration: 10000 nM
Compound 4: middle estimate off by 10-fold (1.00 log units), on the high side; the measured number lies below the stated range.
By their numbers in this assay, from the lowest: compound 4; then compounds 1, 2 and 3 (each within the scatter of the next).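

For the compounds shown here, replacing fluoro with methyl at this place, on an aromatic carbon para to a large group, gives a 10-fold lower number from compound 3 to compound 4 (1.00 log units; beyond the scatter), the first step beyond the scatter in this assay. The substituent on the other aromatic ring matters too: methoxy in place of methyl gives a 10-fold lower number from compound 2 to compound 4 (1.00 log units; beyond the scatter) and methoxy in place of hydrogen gives a 10-fold lower number from compound 1 to compound 4 (1.00 log units; beyond the scatter), whereas methyl in place of hydrogen there gave no change at the digits printed from compound 1 to compound 2 (within the scatter). Neither the 4-methylphenyl group in compounds 1 and 2 nor the methoxy in compound 3 goes with a lower number without the other, and only compound 4 carries both.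

No measurement at hand explains this pairing. Going by these compounds, whether a chloro or ethyl at this place, or a hydroxyl or amine in place of the methoxy, would keep the lower number remains open.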